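The compounds below may be only part of what the source reports. "The series", "measured", "known", "first", "only" and "open" are said of these compounds alone.

Measured so far in a physicochemical assay for solubility, with a stated time of 18 h, at pH 7.4; a higher number here means a more soluble compound, a lower number a less soluble compound:
compound 1 `COc1cccc(CNCCCNc2ccnc3cc(C4CCCCC4)ccc23)c1O` gives 4200 nM
compound 2 `COc1ccc(F)cc1CNCCCNc1ccnc2cc(C3CCCCC3)ccc12` gives 4200 nM
compound 3 `COc1cccc(CNCCCNc2ccnc3cc(-c4ccc(C(C)(C)C)cc4)ccc23)c1O` gives 32000 nM

Compound 2 stands level with compound 1 at the digits printed, the two together the lowest of the three numbers: no change at the digits printed from compound 1 to compound 2 (within the scatter). Among the measured compounds shown here, compound 3 is furthest from compound 2, and the step to it from compound 1 is the only change measured at the aromatic carbon of the core: a 7.6-fold higher number from compound 1 to compound 3 (0.88 log units; beyond the scatter).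

Compound 4 `COc1ccc(F)cc1CNCCCNc1ccnc2cc(CC(C)C)ccc12` has not yet been measured. It differs from compound 2 in one place: isobutyl in place of cyclohexyl on an aromatic carbon.

For the measured compounds named here, of the measured steps, only the one from compound 1 to compound 3 touches this aromatic carbon, and it was modest; there a ring of the same kind was exchanged for a larger aromatic group, whereas here a shorter chain with no ring enters. The step from compound 1 to compound 2 sits at the saturated chain carbon and gives no guidance here. A modest rise in this assay is therefore expected, smaller than the step already seen at this carbon, with the direction not firmly fixed by the data.

Compound 4 is expected at 8000 nM, within 3000 nM to 22000 nM, which means an expected step of a 1.9-fold higher number from compound 2 to compound 4 (0.28 log units; within the scatter).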

Compound 4, solubility: 4200 nM
For compound 4 the middle estimate is 1.9-fold (0.28 log units) above the measured one, within the range that was stated.
By their numbers in this assay, from the lowest: compounds 1, 2 and 4 (each within the scatter of the next); then compound 3.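

The exchange of cyclohexyl for isobutyl on the aromatic carbon gives no change at the digits printed from compound 2 to compound 4 (within the scatter) in this assay on the 5-fluoro-2-methoxyphenyl background, so at this position the read-out does not separate the ring from the shorter open chain. Until now this carbon could be read only through a 7.6-fold higher number from compound 1 to compound 3 (0.88 log units; beyond the scatter) with 4-(tert-butyl)phenyl entering, and among the groups shown there only that aromatic group stands apart from cyclohexyl, although on a different background from the isobutyl step. No measurement here bears on what lies behind either step.

Going by these compounds, it remains open whether an amine, a carboxylic acid or a longer alkyl chain on this aromatic carbon would read level with isobutyl and cyclohexyl or move the number in this assay in either direction. Also open, on these data alone, is whether the two changes carry over between backgrounds, with isobutyl on the 2-hydroxy-3-methoxyphenyl side chain of compound 1 and 4-(tert-butyl)phenyl on the 5-fluoro-2-methoxyphenyl side chain of compound 2.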